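Chloro in place of methyl on two related cores

This account rests on a few compounds, and the source may have more. Where it says the series, first, only, none or still open, it means among the compounds named here.

Compound 1 `Cc1cccc2c1c([N+](=O)[O-])cc[n+]2[O-]` and compound 2 `Cc1ccc2c([N+](=O)[O-])cc[n+]([O-])c2c1` are built from the same atoms joined differently; the difference between the two cores is not broken down here. In a physicochemical assay for lipophilicity (a lower number here means a more polar compound, a higher number a more lipophilic compound), compound 1 gives 1.25 and compound 2 gives 1.49, the two within the scatter of each other. Compound 3 `O=[N+]([O-])c1cc[n+]([O-])c2cc(Cl)ccc12` carries chloro in place of methyl on an aromatic carbon and gives 1.75, the step being a number 0.26 log units higher from compound 2 to compound 3 (within the scatter). Compound 4 `O=[N+]([O-])c1cc[n+]([O-])c2cccc(Cl)c12` carries the same kind of change on the core of compound 1, (chloro in place of methyl on an aromatic carbon); around the place it is ortho to a fused ring and meta to a fused ring, where in compound 3 it is meta to a fused ring and para to a fused ring. The expected step is a number 0.26 log units higher from compound 1 to compound 4 (within the scatter), resting on the step of a number 0.26 log units higher from compound 2 to compound 3 (within the scatter). For compound 4 the estimate in this assay is 1.51, with most repeats expected between 1.21 and 1.81.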

Compound 4, partition coefficient: 1.75
For compound 4 the middle estimate is 0.24 log units below the measured one; low and high end bracket the measured number.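

In this assay, within the data shown here, chloro in place of methyl on an aromatic carbon gives a number 0.50 log units higher from compound 1 to compound 4 (beyond the scatter), whereas on the other core the same change gives a number 0.26 log units higher from compound 2 to compound 3 (within the scatter), so only the step on the core of compound 1 stands clear of the scatter. With one pair per core, this does not show that the step differs in size between the two cores, nor that it would hold on a further core. Nothing shown here bears on why the step on the core of compound 1 has this size.

Open, from the compounds shown here alone, is how an amine or a carboxylic acid in place of methyl on these aromatic carbons would read. Also open, going by these compounds, is whether the chloro for methyl step would look the same in any other kind of assay.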